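The source may hold more compounds than are shown below. What is called first, only, known or untested is meant among the compounds shown, and "the series" means these compounds.

Compound 1 `CC1=C(C(=O)OCc2ccccc2)C(c2ccco2)NC(=O)N1` is the reference point for the series. In an assay on membranes from HEK293 cells for displacement of a labelled ligand from adenosine receptor A2b (Homo sapiens), read by scintillation counting, with a stated time of 30 min (a higher number here means a weaker inhibitor, a lower number a stronger inhibitor), compound 1 gives 887 nM. Compound 2 `CC1=C(C(=O)OCc2ccccc2)C(c2ccoc2)NC(=O)N1` differs from compound 1 by furan-3-yl in place of furan-2-yl on a saturated ring carbon, and in this assay compound 2 gives 6650 nM; the step is a 7.5-fold higher number from compound 1 to compound 2 (0.87 log units; beyond the scatter). Compound 3 `CCC(C)OC(=O)C1=C(C)NC(=O)NC1c1ccco1` keeps the furan-2-yl and changes the ester side instead, (sec-butyl in place of benzyl on an oxygen next to a carbonyl group); in this assay compound 3 gives 84.3 nM, a step of an 11-fold lower number from compound 1 to compound 3 (1.02 log units; beyond the scatter), and it holds the lowest number of the three measured compounds.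

Compound 4 `CCC(C)OC(=O)C1=C(C)NC(=O)NC1c1ccoc1` has not been measured. It differs from compound 3 by furan-3-yl in place of furan-2-yl on a saturated ring carbon. Going by the values given here, this is the same kind of change as the one from compound 1 to compound 2; the surroundings are described alike except that in compound 3 the furan sits next to the ring atom that bears a group of 7 heavy atoms, whereas in compound 1 it sits next to the ring atom that bears a large group. The cores of compound 1 and compound 3 differ by sec-butyl in place of benzyl on an oxygen next to a carbonyl group.

The expectation for compound 4 rests on the single earlier occurrence of this change, a 7.5-fold higher number from compound 1 to compound 2 (0.87 log units; beyond the scatter), and is a step of a 7.5-fold higher number from compound 3 to compound 4 (0.87 log units; beyond the scatter) in this assay. Compound 4 is accordingly estimated at 630 nM, with a range from 250 nM to 1600 nM.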

Compound 4, inhibition constant: 201 nM
Estimate against measurement, compound 4: 3.1-fold (0.50 log units) above; measured number below the stated range.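

In this assay, furan-3-yl in place of furan-2-yl gives a higher number on both cores, and on the sec-butyl core the step is smaller (a 2.4-fold higher number from compound 3 to compound 4 (0.38 log units; beyond the scatter)), so the direction carries across but the size does not: the same change on two cores in this assay, a 7.5-fold higher number (0.87 log units; beyond the scatter) from compound 1 to compound 2 and a 2.4-fold higher number (0.38 log units; beyond the scatter) from compound 3 to compound 4, 3.1-fold (0.50 log units) apart, beyond the scatter of two such steps.

Read the other way, sec-butyl in place of benzyl gives a lower number with either furan, and the step is larger with furan-3-yl (a 33-fold lower number from compound 2 to compound 4 (1.52 log units; beyond the scatter)), so here too the direction holds while the size depends on the partner group: the same change on two cores in this assay, an 11-fold lower number (1.02 log units; beyond the scatter) from compound 1 to compound 3 and a 33-fold lower number (1.52 log units; beyond the scatter) from compound 2 to compound 4, 3.1-fold (0.50 log units) apart, beyond the scatter of two such steps.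

These four compounds form a single pair of pairs, which shows that the two changes are not independent in this series but cannot show why, nor whether the same holds on any other core.

From the compounds shown here alone, it remains open whether the order of the two furans holds with other ester groups, such as a longer chain like n-hexyl or a small one like ethyl. Going by these compounds, it is equally open how a thiophene or a phenyl ring in place of either furan would behave on these two cores.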